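This account rests on a few compounds, and the source may have more. Where it says the series, first, only, none or still open, it means among the compounds named here.

Measured so far:
- compound 1 `CC(C)[C@H](NC(=O)c1cc(Cl)ccc1OCCCCNC(=O)OC(C)(C)C)C(=O)Nc1ccc([N+](=O)[O-])cc1Cl` — > 10000 nM
- compound 2 `CC(C)[C@H](NC(=O)c1cc(Cl)ccc1OCCCCN)C(=O)Nc1ccc([N+](=O)[O-])cc1Cl` — 5590 nM
- compound 3 `CC(C)(C)OC(=O)CC[C@H](NC(=O)c1cc(Cl)ccc1OCCNC(=O)OC(C)(C)C)C(=O)Nc1ccc([N+](=O)[O-])cc1Cl` — > 10000 nM

All three were tested in a functional assay on MDA-MB-231 cells (Homo sapiens) for inhibition, read by MTT assay, with a stated time of 72 h; on this read-out lower numbers stand for stronger inhibition and higher numbers for weaker inhibition. In this assay compound 1 gives > 10000 nM, which is a limit of the assay and not a number. Compound 2 gives 5590 nM in this assay. The change between them is hydrogen in place of tert-butoxycarbonyl on an amine nitrogen, and the step it made is an at least 1.7-fold lower number from compound 1 to compound 2 (0.25 log units; that floor lies within the scatter). Compound 3 gives > 10000 nM in this assay, again a limit of the assay rather than a number. Two of the three values sit at the limit of > 10000 nM in this assay, at which 2 of the 3 values shown sit, so the series is read mostly against that limit. The difference between the core of compound 1 and the core of compound 3 is not broken down here.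

Compound 4 `CC(C)(C)OC(=O)CC[C@H](NC(=O)c1cc(Cl)ccc1OCCN)C(=O)Nc1ccc([N+](=O)[O-])cc1Cl` has not been measured. It differs from compound 3 by hydrogen in place of tert-butoxycarbonyl on an amine nitrogen, the same change as that from compound 1 to compound 2: the place line is the same word for word in both cases, an amine nitrogen whose other neighbours are a saturated chain carbon. Within the data shown here, the step from compound 3 to compound 4 in this assay is expected to be about an at least 1.4-fold lower number from compound 3 to compound 4 (0.15 log units; that floor lies within the scatter), of the same order as the earlier step, since that rests on the one measured pair, where the change gave an at least 1.7-fold lower number from compound 1 to compound 2 (0.25 log units; that floor lies within the scatter) from a starting value that was itself a limit. Compound 4 is therefore estimated at 7000 nM in this assay, with a range from 2500 nM to 20000 nM, and a fair chance that only a limit is reported.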

Compound 4, half-maximal inhibitory concentration: 5990 nM
For compound 4 the middle estimate is 1.2-fold (0.07 log units) above the measured one; the range from low to high includes it.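

In this assay, hydrogen in place of tert-butoxycarbonyl on an amine nitrogen gives an at least 1.6-fold lower number from compound 3 to compound 4 (0.22 log units; that floor lies within the scatter), and this sits close to the step on the other core: the same change on two cores in this assay, an at least 1.7-fold lower number (0.25 log units; that floor lies within the scatter) from compound 1 to compound 2 and an at least 1.6-fold lower number (0.22 log units; that floor lies within the scatter) from compound 3 to compound 4; the limit leaves it open whether they differ On both cores, the compound carrying tert-butoxycarbonyl reads only as a limit of the assay, while the compound with the free amine reads as a number, so the observation recurs across the two pairs. It does not establish the true size of the change on either core, or that the change exceeds the usual scatter, since both steps are floors that lie within that scatter and both start from a limit: the limit of > 10000 nM in this assay, at which 2 of the 4 values shown sit.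

The two cores differ both in the chain carrying the amine and in the side chain bearing the tert-butyl ester in compound 4, so the compounds shown do not separate the contribution of either feature. Also open, on these data alone, is how far the reading depends on the free primary amine itself, which could be tested with an acetamide or a dimethylamine on the same chain, and whether a carboxylic acid in place of the tert-butyl ester would read differently.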